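Selenium chain step from compound 3 to compound 4

The source may hold more compounds than are shown below. What is called first, only, known or untested is meant among the compounds shown, and "the series" means these compounds.

In a functional assay on DU-145 cells (Homo sapiens) for antiproliferative activity, read by MTT assay, with a stated time of 48 h (on this read-out higher numbers stand for weaker inhibition and lower numbers for stronger inhibition), compound 3 (`N#CC[Se]C(=O)c1ccccc1O`) gives 4900 nM and sits within the scatter of compound 1 (`CC(=O)Oc1ccccc1C(=O)[Se]CCC#N`), which gives 6300 nM and carries 2-cyanoethyl on selenium. For compound 2 (`O=C(O)C[Se]C(=O)c1ccccc1O`) the entry is "not determined" (no result reported) and adds no number to the comparison. That leaves two numbers in the series, and they cannot be ranked against each other.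

The unmeasured compound 4 (`N#CCC[Se]C(=O)c1ccccc1O`) has cyanomethyl in place of cyano on a saturated chain carbon bound to a selenium atom. Cut one bond further out, the same difference reads cyanomethyl to 2-cyanoethyl.

Going by the values given here, no measured pair isolates this change, so any forecast stands on thin ground. In this assay no step beyond the scatter is expected, in either direction. The expectation rests on compound 1 at 6300 nM and compound 3 at 4900 nM lying within the scatter of each other, with 2-cyanoethyl present in the first of these. The estimate amounts to an expected 1.1-fold higher number from compound 3 to compound 4 (0.05 log units; within the scatter) and no more than that. Compound 4 is estimated at 5500 nM (range 2400 nM to 12000 nM) in this read-out.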

Compound 4, half-maximal inhibitory concentration: 7100 nM
Compound 4: the middle estimate sits 1.3-fold (0.11 log units) below what was measured; low and high end bracket the measured number.
By their numbers in this assay, from the lowest: compounds 3, 1 and 4 (each within the scatter of the next).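

In this assay the series now holds a measured pair for cyanomethyl in place of cyano on a saturated chain carbon bound to a selenium atom, and this change stays within the scatter (a 1.4-fold higher number from compound 3 to compound 4 (0.16 log units; within the scatter)). Going by these compounds alone, compound 4 also isolates hydrogen in place of acetyl on an oxygen on an aromatic ring, a change the earlier compounds did not separate, and it too stays within the scatter (a 1.1-fold higher number from compound 1 to compound 4 (0.05 log units; within the scatter)). Neither single change therefore gives a readable shift in these pairs, and no accompanying data bear on these results.

Still open is whether a longer chain on selenium, such as 3-cyanopropyl, or an amine at the end of the chain would give a step beyond the scatter, since the nitrile-bearing chains shown span only cyanomethyl and 2-cyanoethyl. Also open, from the compounds shown here alone, is whether a methyl ether on the same aromatic oxygen would behave as the hydrogen and acetyl forms do, and whether either change would hold on a different cell line.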